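The source may hold more compounds than are shown below. What is called first, only, known or untested is meant among the compounds shown, and "the series" means these compounds.

In a functional assay on NCI-H157 cells (Homo sapiens) for cytotoxicity, read by resazurin assay, with a stated time of 72 h (on this read-out higher numbers stand for weaker inhibition and lower numbers for stronger inhibition), compound 3 (`COc1cc(/C=C/C(=O)OCCCCCO[N+](=O)[O-])ccc1O`) gives 13400 nM as the lower of the two numbers, while compound 1 (`COc1cc(/C=C/C(=O)OCCCCCCO[N+](=O)[O-])ccc1O`) gives 32100 nM as the higher. Compound 2 (`COc1cc(/C=C/C(=O)OCCCO[N+](=O)[O-])ccc1OCCCO[N+](=O)[O-]`) reads > 50000 nM and this is a limit of the assay, not a number. Compound 4 (`COc1cc(/C=C/C(=O)OCCCO[N+](=O)[O-])ccc1O`) has nitrooxy in place of 2-(nitrooxy)ethyl on a saturated chain carbon, three bonds along the chain from an oxygen next to a carbonyl group. Among the compounds with values here, the one measured step of this kind is a 2.4-fold lower number from compound 1 to compound 3 (0.38 log units; beyond the scatter) and it is modest, so it gives only weak support for a further fall. In this assay the expected result is a 1.0-fold higher number from compound 3 to compound 4 (0.02 log units; within the scatter) with no step beyond the scatter expected in either direction. For compound 4 the estimate is 14000 nM (expected range 5000 nM to 45000 nM).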

Compound 4, half-maximal inhibitory concentration: 20500 nM
The estimate for compound 4 lay 1.5-fold (0.17 log units) below the measured number; the range from low to high includes it.
By their numbers in this assay, from the lowest: compounds 3, 4 and 1 (each within the scatter of the next, the first and the last beyond it). At a limit, above all of these: compound 2.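

In this assay, nitrooxy in place of 2-(nitrooxy)ethyl gives a 1.5-fold higher number from compound 3 to compound 4 (0.18 log units; within the scatter), and nitrooxy in place of 3-(nitrooxy)propyl gives a 1.6-fold lower number from compound 1 to compound 4 (0.19 log units; within the scatter), so compound 4 is not separated from either compound on this chain. The earlier step between compound 1 and compound 3 therefore does not extend into a steady trend with chain length. Compound 2 reads as a limit, not a number, so hydrogen in place of 3-(nitrooxy)propyl on an oxygen on an aromatic ring gives an at least 2.4-fold lower number from compound 2 to compound 4 (0.38 log units; beyond the scatter).

Open, going by these compounds, is whether a longer chain than that of compound 1 would follow the same flat course. Also open, on these data alone, is whether an amine in place of the nitrooxy end would change the number.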